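A Naphthyl Swap on a Series Without Measurable Potency

The compounds below may be only part of what the source reports. "The series", "measured", "known", "first", "only" and "open" are said of these compounds alone.

Compound 1 `CCOC(=O)C1=Cc2ccccc2OC1(OCc1cc(-c2ccc(F)cc2F)no1)C(F)(F)F` was tested in a functional assay on HeLa cells (Homo sapiens) for inhibition, read by MTT assay, with a stated time of 24 h; a lower number here means a stronger inhibitor, a higher number a weaker inhibitor. Compound 1 gives > 150000 nM there, which is a limit of the assay and not a number. Compound 2 `CCOC(=O)C1=Cc2ccccc2OC1(OCc1cn(-c2cccc(OC)c2)nn1)C(F)(F)F` gives > 150000 nM in this assay, again a limit. Compound 3 `CCCCCCCCn1cc(COC2(C(F)(F)F)Oc3ccccc3C=C2C(=O)OCC)nn1` gives > 150000 nM in this assay, also a limit. The one single-point step among these, a step that the two limits leave unreadable from compound 2 to compound 3, therefore has no readable size, and the values of compound 1 and compound 2 show only that both sit at the limit.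

Compound 4 `CCOC(=O)C1=Cc2ccccc2OC1(OCc1cc(-c2ccc3ccccc3c2)no1)C(F)(F)F` differs from compound 1 in one place: naphthalen-2-yl in place of 2,4-difluorophenyl on an aromatic carbon. For the measured compounds named here, no measured step touches this change. What is known is summed up by the limit of > 150000 nM in this assay, at which 3 of the 3 values shown sit, so a number is unlikely to appear. Compound 4 is expected to give 200000 nM in this assay, most plausibly between 50000 nM and 1000000 nM. The expected step that the limit leaves unreadable from compound 1 to compound 4 is thus estimated to stay within the scatter, with a limit the likeliest outcome.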

Compound 4, half-maximal inhibitory concentration: > 150000 nM
Compound 4: a limit, no number; the forecaster's own chance of this, stated with the estimate: 85%; the middle value is on the limit's open side.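

No new step can be read: compound 1 and compound 4 both give only a limit in this assay, so the change from 2,4-difluorophenyl to naphthalen-2-yl has no readable size. The compounds shown leave open which change, if any, would yield an actual number: the limit of > 150000 nM in this assay, at which 4 of the 4 values shown sit.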